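This account rests on a few compounds, and the source may have more. Where it says the series, first, only, none or still open, it means among the compounds named here.

Compound 2 `CC(C)c1ccc2[nH]c(=O)c(CN(Cc3ccc(F)cc3)Cc3ccc(C(C)(C)C)cc3)cc2c1` was measured in a toxicity assay on MDCK cells (Canis lupus familiaris) for cytotoxicity, read by crystal violet staining, with a stated time of 48 h (a lower number here means that less compound is tolerated, a higher number that more compound is tolerated), and gives 7900 nM. Among the compounds with values here, its one comparator is compound 1 `CCCc1ccc2[nH]c(=O)c(CN(Cc3ccc(F)cc3)Cc3ccc(C(C)(C)C)cc3)cc2c1`, which in this assay gives 8400 nM. Within the data shown here, the step of a 1.1-fold lower number from compound 1 to compound 2 (0.03 log units; within the scatter) is the only measured step, and it separates the two compounds by no more than the usual scatter, so compound 2 and compound 1 stand at practically the same level in this assay.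

Compound 3 `CC(C)c1ccc2[nH]c(=O)c(CN(Cc3ccc(C(C)(C)C)cc3)C(C)c3ccc(F)cc3)cc2c1` has not yet been measured. It differs from compound 2 by methyl in place of hydrogen on a saturated chain carbon bound to an amine nitrogen and an aromatic carbon. Among the measured compounds shown here, no measured step touches this change: the only step available, a 1.1-fold lower number from compound 1 to compound 2 (0.03 log units; within the scatter), concerns a group on an aromatic carbon of the shared core, not the saturated chain carbon bound to the amine nitrogen and the aromatic carbon, and it was within the scatter in any case. With nothing in the data pointing to a shift in either direction, the reasonable expectation for compound 3 in this assay is a step of no change at the digits printed from compound 2 to compound 3 (within the scatter), that is, no change beyond the scatter. Compound 3 is therefore estimated at 7900 nM, with a plausible range from 3000 nM to 20000 nM.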

Compound 3, half-maximal cytotoxic concentration: 13100 nM
Estimate against measurement, compound 3: 1.7-fold (0.22 log units) below, within the range that was stated.
By their numbers in this assay, from the lowest: compounds 2, 1 and 3 (each within the scatter of the next).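

Within the data shown here, compound 3 gives the first reading at a place other than the aromatic carbon of the shared core. In this assay, the exchange of 4-fluorobenzyl for 1-(4-fluorophenyl)ethyl gives a 1.7-fold higher number from compound 2 to compound 3 (0.22 log units; within the scatter), so methyl in place of hydrogen on this saturated chain carbon bound to an amine nitrogen and an aromatic carbon brings no shift that can be told from the scatter, just as the change on the aromatic carbon gave a 1.1-fold lower number from compound 1 to compound 2 (0.03 log units; within the scatter). The data offer no explanation for how this reading comes about.

What remains open is whether this saturated chain carbon would hold the same level with a larger or different group, such as ethyl, hydroxymethyl, an amine or a carboxylic acid, since methyl is the only group shown there besides hydrogen. The compounds shown also leave open whether the same methyl would give a similar reading on a core carrying propyl in place of isopropyl, and whether a change at any other place would move the number beyond the scatter.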